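The source may hold more compounds than are shown below. What is called first, only, known or untested is meant among the compounds shown, and "the series" means these compounds.

Of the compounds shown here, three that share one core have been measured in an ADME assay on Vero cells (Chlorocebus sabaeus) for cytotoxicity, read by neutral red uptake, tested at 3150 ug/mL; on this read-out higher numbers stand for a weaker effect at the one concentration tested and lower numbers for a stronger effect. Compound 1 `O=C1CSC(c2ccc([N+](=O)[O-])cc2)N1CCN1CCCCC1` gives 10%, compound 2 `COc1ccccc1C1SCC(=O)N1CCN1CCCCC1` gives 5%, and compound 3 `COc1cccc(C2SCC(=O)N2CCN2CCCCC2)c1` gives 6%. In this assay the number for compound 2 sits within the usual scatter of the numbers for compound 1 and compound 3, so the three compounds cannot be told apart on these data; none of them shows more than a weak effect at the one concentration tested.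

The step goes from compound 2 to compound 4 `O=C1CSC(c2ccccc2Cl)N1CCN1CCCCC1`, which differs from compound 2 in one place: chloro in place of methoxy on an aromatic carbon. Within the data shown here, no pair of measured compounds shows the effect of this or any other single change, so there is no measured step to lean on. Given that all three measured numbers lie close together, the step from compound 2 to compound 4 is expected to be a number 2 percentage points higher from compound 2 to compound 4 (within the scatter), that is, no change beyond the scatter in either direction. For compound 4 the estimated value in this assay is therefore 7%, with a range from 0% to 20%.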

Compound 4, a percentage reported as activity, at one concentration (the size of the read-out at that concentration, not a potency): 22%
Beside the measured number, compound 4's estimate is 15 percentage points below it; the measured number lies above the stated range.
By their numbers in this assay, from the lowest: compounds 2, 3 and 1 (each within the scatter of the next); then compound 4.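

In this assay, among these compounds, putting chloro in place of methoxy on this aromatic carbon, ortho to a large group, gives the first step that stands clear of the scatter: a number 17 percentage points higher from compound 2 to compound 4 (beyond the scatter), which on this read-out means a weaker effect at the one concentration tested. The earlier compounds shown here, whose numbers all lay within the scatter of one another, gave no sign that a single change could shift the number this much, and this pair shows that the group on this carbon can matter. The data give no measured explanation for the step.

As far as these compounds go, it remains open whether the step comes from chloro entering or from methoxy leaving; fluoro, methyl or a plain hydrogen on the same carbon would help separate the two. From the compounds shown here alone, it is also open whether chloro on another carbon of the aromatic ring would give a similar step.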